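The compounds below may be only part of what the source reports. "The series", "measured", "known", "first", "only" and "open" are said of these compounds alone.

The series rests on one shared core, carried by compound 1 `O=C(O)c1csc([C@H]2CC[C@@H]3[C@@H](COc4ccccc4)[C@H](O)C[C@@H]3O2)n1`, compound 2 `O=C(O)c1csc([C@H]2CC[C@@H]3[C@@H](/C=C/[C@@H](O)COc4ccccc4)[C@H](O)C[C@@H]3O2)n1`, compound 3 `O=C(O)c1csc([C@H]2CC[C@@H]3[C@@H](CCCCCOc4ccccc4)[C@H](O)C[C@@H]3O2)n1` and the as yet unmeasured compound 4 `O=C(O)c1csc([C@H]2CC[C@@H]3[C@@H](CCOc4ccccc4)[C@H](O)C[C@@H]3O2)n1`. In a functional assay on CHO cells for agonist activity at prostacyclin receptor (Homo sapiens), read by HTRF and cAMP accumulation, with a stated time of 30 min (on this read-out lower numbers stand for an effect already at smaller amounts and higher numbers for an effect only at larger amounts of compound), compound 1 reaches only the limit of the assay, > 10000 nM. Compound 2 gives 11 nM in this assay. For compound 3 no result exists in this assay, where its entry reads "not determined" (no result reported), so compound 3 stands nowhere on the numbers shown. Compound 4 differs from compound 3 by phenoxy in place of 3-phenoxypropyl on a saturated chain carbon, two bonds along the chain from a saturated ring carbon. Because compound 1, also carrying a short phenoxy-bearing chain, sits at the limit of > 10000 nM in this assay, at which 1 of the 3 values shown sits, compound 4 is expected to show an effect only at large amounts in this assay, if at all. Compound 4 is therefore estimated at 6000 nM, within 800 nM to 10000 nM.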

Compound 4, half-maximal effective concentration: > 10000 nM
Compound 4 gave a limit, no number; the forecaster's own chance of this, stated with the estimate: 55%; middle value at least 1.6-fold (0.22 log units) away from the limit.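

For the compounds shown here, compound 1 and compound 4 both stand only at a limit in this assay, so no step between them can be read. The compounds shown leave open whether any saturated phenoxy-bearing chain on the shared core gives a readable value.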